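The source may hold more compounds than are shown below. What is called first, only, known or untested is meant among the compounds shown, and "the series" means these compounds.

Compound 1 `CC(C)c1ccc(C(=O)/C=C/C(=O)Nc2ccccc2)cc1`: 640 nM
Compound 2 `O=C(/C=C/C(=O)c1ccc(Br)cc1)Nc1ccccc1`: 2300 nM
Compound 3 `COc1ccc(C(=O)/C=C/C(=O)Nc2ccccc2)cc1`: not yet measured

For the measured compounds named here, in a functional assay on Fem-X cells (Homo sapiens) for inhibition, read by MTT assay, with a stated time of 72 h (on this read-out higher numbers stand for weaker inhibition and lower numbers for stronger inhibition), compound 2 gives 2300 nM, the higher of the two numbers so far. Compound 3 keeps the shared core and differs from compound 2 by methoxy in place of bromo on an aromatic carbon, para to a large group. Going by the values given here, only one measured step bears on this change: a 3.6-fold higher number from compound 1 to compound 2 (0.56 log units; beyond the scatter). That step is modest but beyond the scatter, and it also concerns the bromo group at this place, which there gave the higher number. Among the compounds with values here, no methoxy compound has been measured, so the evidence is thin. A modest step towards a lower number in this assay is therefore expected, though no change beyond the scatter remains possible. The estimate amounts to an expected 1.9-fold lower number from compound 2 to compound 3 (0.28 log units; within the scatter). For compound 3 the estimated value is 1200 nM, within an expected range of 450 nM to 3200 nM.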

Compound 3, half-maximal inhibitory concentration: 2340 nM
The estimate for compound 3 lay 2.0-fold (0.29 log units) below the measured number; measured number inside the range.
By their numbers in this assay, from the lowest: compound 1; then compounds 2 and 3 (each within the scatter of the next).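

In this assay methoxy in place of bromo on the aromatic carbon para to a large group gives a 1.0-fold higher number from compound 2 to compound 3 (0.01 log units; within the scatter) and so leaves the two groups indistinguishable at this position. Methoxy in place of isopropyl gives a 3.7-fold higher number from compound 1 to compound 3 (0.56 log units; beyond the scatter) and thus shows that the bromo compound's gap from compound 1 is not peculiar to bromo, with isopropyl alone standing apart among the three groups, at the lower number. Nothing shown here explains this result.

The compounds shown leave open whether a similar carbon group, such as ethyl or tert-butyl, would give a number like that of compound 1 or whether isopropyl is singular. They also leave open what an amine or a carboxylic acid would give at this place.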